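The source may hold more compounds than are shown below. What is called first, only, known or untested is meant among the compounds shown, and "the series" means these compounds.

Measured so far in an ADME assay on HCT-116 cells (Homo sapiens) for cytotoxicity, read by CellTiter-Glo, with a stated time of 72 h; a lower number here means a stronger inhibitor, a higher number a weaker inhibitor:

Compound 1 `CC1CCN(C2CCN(S(=O)(=O)c3ccc(-c4ccccc4F)cc3)CC2)CC1` gives > 5000 nM, which is a limit of the assay and not a number.
Compound 2 `CC1CCN(C2CCN(S(=O)(=O)c3ccc(-c4ccc(Cl)cc4)cc3)CC2)CC1` gives > 5000 nM, again a limit.
Compound 3 `CC1CCN(C2CCN(S(=O)(=O)c3ccc(OC(F)(F)F)cc3)CC2)CC1` gives > 5000 nM, again a limit.

The three compounds share one core and differ only in the group attached to an aromatic carbon. Compound 3 stands where the other two stand: at the limit, with no measured number of its own. The steps between them, a step that the two limits leave unreadable from compound 1 to compound 2, a step that the two limits leave unreadable from compound 1 to compound 3 and a step that the two limits leave unreadable from compound 2 to compound 3, cannot be read in size or direction because of the limit of > 5000 nM in this assay, at which 3 of the 3 values shown sit.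

Compound 4 `CC1CCN(C2CCN(S(=O)(=O)c3ccc(C(C)(C)C)cc3)CC2)CC1` is the next compound to be measured. It differs from compound 3 in one place: tert-butyl in place of trifluoromethoxy on an aromatic carbon. Going by the values given here, no measured step bears directly on this exchange, and the three steps that exist are all unreadable, so there is no measured basis for expecting a readable shift in either direction. The step from compound 3 to compound 4 is therefore estimated as a step that the limit leaves unreadable from compound 3 to compound 4, which amounts to staying at the limit. For compound 4 the estimated value in this assay is 8000 nM, with a range from 3000 nM to 30000 nM, and most likely the assay will again report only a limit.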

Compound 4, half-maximal inhibitory concentration: > 5000 nM
Compound 4: only a limit was reported (the forecaster's own chance of this, stated with the estimate: 80%); the middle value lies beyond the limit too.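

In this assay compound 4 gives > 5000 nM, which is a limit of the assay and not a number. Going by these compounds alone, no step from compound 1, compound 2 or compound 3 to compound 4 can be read, because all four compounds rest on one limit: the limit of > 5000 nM in this assay, at which 4 of the 4 values shown sit. The compounds shown leave open whether any group on this aromatic carbon gives a measured number, and so which exchange there makes a difference.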